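Acetoxy for isobutoxy on a weakly inhibiting series

A few compounds are considered here, and "the series" means these few. Any claim that something is new, unique, unknown or untested is made for them only; others in the source may bear on it.

In a functional assay on MCF7 cells (Homo sapiens) for inhibition, read by MTT assay, with a stated time of 72 h, tested at 30 ug/mL (a higher number here means more inhibition of growth at the concentration tested, a lower number less inhibition of growth), compound 1 (`C=C1[C@H](OCC(C)C)C[C@@H](OC(=O)c2cccnc2)C(C)(C)/C=C/[C@@H](C)C(=O)[C@@]2(OC(C)=O)C[C@H](C)[C@H](OC(C)=O)[C@@H]2[C@H]1OC(C)=O`) gives 14.4% while compound 2 (`C=C1[C@H](OCC(C)C)C[C@@H](OC(=O)c2cccnc2)C(C)(C)/C=C/[C@@H](C)C(=O)[C@@]2(OC(C)=O)C[C@@](C)(OC(C)=O)[C@H](OC(C)=O)[C@@H]2[C@H]1OC(C)=O`) gives 16.7% and these two values lie within the scatter of each other. Going by the values given here, compound 2 therefore stands level with compound 1, the only other measured compound, and both show modest growth inhibition at the concentration tested.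

Compound 3 (`C=C1[C@H](OC(C)=O)C[C@@H](OC(=O)c2cccnc2)C(C)(C)/C=C/[C@@H](C)C(=O)[C@@]2(OC(C)=O)C[C@@](C)(OC(C)=O)[C@H](OC(C)=O)[C@@H]2[C@H]1OC(C)=O`) differs from compound 2 in one place, with acetyl in place of isobutyl on an oxygen on a saturated carbon. Cut one bond further out, the same difference reads isobutoxy to acetoxy. Among the compounds with values here, no measured pair shows this exchange, so the data give no direct measure of its size. With compound 1 at 14.4% and compound 2 at 16.7% as the only reference points, no step beyond the scatter is expected in this assay and neither direction is favoured. The expected step is small (a number 1.7 percentage points lower from compound 2 to compound 3 (within the scatter)) and stays within the scatter. For compound 3 the estimate is 15% with 5% to 28% as the expected range.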

Compound 3, percent growth inhibition at one concentration: 36.3%
Estimate against measurement, compound 3: 21.3 percentage points below; the measured number lies above the stated range.
By their numbers in this assay, from the lowest: compounds 1 and 2 (each within the scatter of the next); then compound 3.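

In this assay, going by these compounds alone, this oxygen on a saturated carbon proves sensitive to what it carries: acetyl in place of isobutyl gives a number 19.6 percentage points higher from compound 2 to compound 3 (beyond the scatter) and is the only step so far that clears the scatter. Within the data shown here, the earlier compounds showed only that the shared core inhibits growth modestly with isobutyl in this place, whereas this pair shows that the group here can move the read-out, with compound 3 reaching 36.3% at the single concentration tested. That reading rests on one pair and says nothing yet about potency over a range of concentrations, and no measurement at hand explains the step.

Still open, as far as these compounds go, is whether the gain comes from having an ester carbonyl in this place or simply from losing isobutyl, which a free hydroxyl, a propanoyl or longer acyl chain, or a benzoyl ester here would help separate. Also open, from the compounds shown here alone, is whether the same exchange carries over to the core of compound 1, since one step on one background sets no rule for the series.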